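Cyclobutyl carboxamide in place of methoxycyclohexyl on the amine

The compounds below may be only part of what the source reports. "The series", "measured", "known", "first", "only" and "open" are said of these compounds alone.

Of the compounds shown here, two have been measured in an assay on isolated protein for inhibition of protein kinase C theta type (Homo sapiens), read by TR-FRET, with a stated time of 2 h; on this read-out lower numbers stand for stronger inhibition and higher numbers for weaker inhibition. Compound 1 `CO[C@H]1CC[C@@H](Nc2cc(NCc3cnccc3C(F)(F)F)ncc2C#N)CC1` gives 58 nM and stands as the lower of the two numbers. Compound 2 `COc1ncncc1CNc1cc(N[C@H]2CC[C@@H](O)CC2)c(C#N)cn1` gives 800 nM in this assay, a gap from compound 1 that lies beyond the scatter; the two differ at more than one place, so nothing is attributed to a single change.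

Compound 3 `CC1(C)[C@@H](Nc2cc(NCc3cnccc3C(F)(F)F)ncc2C#N)C[C@H]1C(N)=O` is not yet measured. It differs from compound 1 at one place: 3-carbamoyl-2,2-dimethylcyclobutyl in place of 4-methoxycyclohexyl on a nitrogen on an aromatic ring. The 4-methoxycyclohexyl leaves and the 3-carbamoyl-2,2-dimethylcyclobutyl enters on a nitrogen on an aromatic ring whose other neighbours are aromatic carbon; a hydrogen-bond donor comes in with it, and a four-membered ring replaces a six-membered one.

Among the compounds with values here, no measured pair isolates this change, so only a modest step is expected, with no firm direction. Compound 3 is expected to give 100 nM in this assay, within 25 nM to 400 nM. The step of a 1.7-fold higher number from compound 1 to compound 3 (0.24 log units; within the scatter) is estimated to stay close to the scatter.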

Compound 3, half-maximal inhibitory concentration: 140 nM
The estimate for compound 3 lay 1.4-fold (0.15 log units) below the measured number, and the stated range covers the measured number.
By their numbers in this assay, from the lowest: compound 1; then compound 3; then compound 2.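

In this assay, within the data shown here, this change on the nitrogen on the aromatic ring gives the only single-place reading so far: 3-carbamoyl-2,2-dimethylcyclobutyl in place of 4-methoxycyclohexyl gives a 2.4-fold higher number from compound 1 to compound 3 (0.38 log units; beyond the scatter), a modest step. The position therefore accepts a four-membered ring and a substituent with a hydrogen-bond donor at a modest cost, without the large step that a change of this kind might have produced. Nothing measured on hand bears on why the number moves.

The four-membered ring, the dimethyl substitution and the carbamoyl group all enter together, so their separate shares in the step remain unresolved. Also open, as far as these compounds go, is how an unsubstituted cyclobutyl, or a cyclohexyl carrying a carboxylic acid or an amine in place of the methoxy group, would read in this assay.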